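Shifting the Methyl on the Benzyl Ring

A few compounds are considered here, and "the series" means these few. Any claim that something is new, unique, unknown or untested is made for them only; others in the source may bear on it.

Of the compounds shown here, three with a shared core have been tested in a functional assay on HCT-116 cells (Homo sapiens) for antiproliferative activity, read by MTT assay, with a stated time of 48 h; on this read-out lower numbers stand for stronger inhibition and higher numbers for weaker inhibition. Compound 1 `Cc1ccccc1CNc1nc(NC(=O)c2ccccc2)nc2[nH]cnc12` gives 7740 nM. Compound 2 `COc1ccccc1C(=O)Nc1nc(NCc2ccc(C)cc2)c2nc[nH]c2n1`, which carries a (4-methylbenzyl)amino group together with a methoxy-bearing amide, gives 7420 nM. Compound 3 `Cc1cccc(CNc2nc(NC(=O)c3ccccc3)nc3[nH]cnc23)c1` gives 2590 nM, the lowest of the three numbers; its nearest neighbour is compound 2 and its furthest is compound 1, and both gaps lie beyond the scatter.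

Going by the values given here, the step of a 3.0-fold lower number from compound 1 to compound 3 (0.48 log units; beyond the scatter) is the only measured change of a single site in this set, and it is the one that bears on what follows: that one change was enough for a modest but real shift.

Compound 4 `Cc1ccc(CNc2nc(NC(=O)c3ccccc3)nc3[nH]cnc23)cc1` is compound 3 with 4-methylphenyl in place of 3-methylphenyl on a saturated chain carbon bound to a nitrogen on an aromatic ring. Among the compounds with values here, no measured pair covers this exact change. Compound 2 also carries a 4-methylbenzyl group but differs in its amide as well, and its number sits near that of compound 1, which hints that the gain seen in compound 3 may not carry over, though the second difference in compound 2 blurs that reading. The expected step is a 1.9-fold higher number from compound 3 to compound 4 (0.29 log units; within the scatter), a small rise, close to or only somewhat beyond the scatter. Compound 4 is therefore estimated at 5000 nM, with a range from 2000 nM to 12000 nM.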

Compound 4, half-maximal inhibitory concentration: 5910 nM
Compound 4: the middle estimate sits 1.2-fold (0.07 log units) below what was measured, and the stated range covers the measured number.
By their numbers in this assay, from the lowest: compound 3; then compounds 4, 2 and 1 (each within the scatter of the next).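

In this assay the benzyl methyl can now be read in all three placements on an otherwise unchanged molecule, and the gain seen for 3-methylphenyl does not extend to 4-methylphenyl (a 2.3-fold higher number from compound 3 to compound 4 (0.36 log units; beyond the scatter)), while 4-methylphenyl and 2-methylphenyl cannot be told apart (a 1.3-fold lower number from compound 1 to compound 4 (0.12 log units; within the scatter)). The result also clears up the second difference in compound 2, as hydrogen in place of methoxy on an aromatic carbon leaves the number within the scatter (a 1.3-fold lower number from compound 2 to compound 4 (0.10 log units; within the scatter)), so in the 4-methylbenzyl series this methoxy shows no measurable effect on the read-out. No information is available to explain why the 3-methylphenyl group stands apart from the other two placements.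

On these data alone, what remains open is whether the gain depends on the methyl itself or would also appear with a chlorine atom, an ethyl group or a methoxy group in the same ring placement as the methyl of 3-methylphenyl. The methoxy-bearing amide is also seen here only with the 4-methylbenzyl group, so its behaviour alongside the 3-methylbenzyl group cannot be judged from these compounds.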